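Swapping the amine end of a soluble chain

The source may hold more compounds than are shown below. What is called first, only, known or untested is meant among the compounds shown, and "the series" means these compounds.

Compound 1 `Cc1ccc2c(c1)[n+]([O-])c(N)n[n+]2[O-]` carries a bare amino group on its core. In a physicochemical assay for solubility, in the presence of a further agent that is not named here (on this read-out higher numbers stand for higher solubility and lower numbers for lower solubility), compound 1 gives 3000000 nM. Compound 2 `CCN(CC)CCNc1n[n+]([O-])c2ccc(C)cc2[n+]1[O-]` carries instead a 2-(diethylamino)ethyl group on that nitrogen. In this assay compound 2 reaches only a limit of the measurement, > 49000000 nM, so its true number is not known. The move an at least 16-fold higher number from compound 1 to compound 2 (1.21 log units; beyond the scatter) is therefore known only as a lower bound, and compound 2 sits at the limit of > 49000000 nM in this assay, at which 1 of the 2 values shown sits.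

Compound 3 `Cc1ccc2c(c1)[n+]([O-])c(NCCN1C(C)CCCC1C)n[n+]2[O-]` keeps the two-carbon chain of compound 2 but changes its far end: 2,6-dimethylpiperidin-1-yl in place of diethylamino on a saturated chain carbon, two bonds along the chain from a nitrogen on an aromatic ring. Among the compounds with values here, no measured step bears directly on exchanging one amine for another at this position; the only measured step concerns adding the whole chain, and it was large. The step of an at least 1.6-fold lower number from compound 2 to compound 3 (0.21 log units; that floor lies within the scatter) is thus an expectation resting on little, and compound 2 itself offers only a bound to start from. For compound 3 the expected solubility in this assay is 30000000 nM, with a range from 5000000 nM to 120000000 nM, and a fair chance that it too returns only a limit.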

Compound 3, solubility: 48000000 nM
For compound 3 the middle estimate is 1.6-fold (0.20 log units) below the measured one; measured number inside the range.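

In this assay compound 3 gives 48000000 nM as a true number and not a limit, so this position now has one chain end with a readable value, and that end carries a six-membered non-aromatic ring where compound 2 has the open diethylamino group. Compound 2 gives > 49000000 nM as a limit of this assay and not as a number. The step of an at least 1.0-fold lower number from compound 2 to compound 3 (0.00 log units; that floor lies within the scatter) is therefore only a floor, and the true distance between the two amine ends cannot be read because one of the pair stands at that limit: the limit of > 49000000 nM in this assay, at which 1 of the 3 values shown sits.

The two methyl groups and the ring of 2,6-dimethylpiperidin-1-yl cannot be told apart here, so a plain piperidin-1-yl or a morpholin-4-yl at the same place would be needed to show which part of the group goes with the value. Going by these compounds, whether a longer three-carbon chain, or a carboxylic acid in place of the amine at the chain end, would give a number of similar size also stays open.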